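This account rests on a few compounds, and the source may have more. Where it says the series, first, only, none or still open, it means among the compounds named here.

Compound 1 `O=C(CSc1nnc(-c2ccncc2)o1)N/N=C/c1ccccc1`: 16700 nM
Compound 2 `O=C(CSc1nnc(-c2ccncc2)o1)N/N=C/c1ccc([N+](=O)[O-])cc1`: 25800 nM
Compound 3 `Cc1ccc(/C=N/NC(=O)CSc2nnc(-c3ccncc3)o2)cc1`: 16800 nM

In a functional assay on SW 1116 cells (Homo sapiens) for cytotoxicity, read by MTT assay, with a stated time of 48 h (on this read-out lower numbers stand for stronger inhibition and higher numbers for weaker inhibition), compound 1 stands at one end of a narrow band, with compound 3 and compound 2 both within the scatter of it. Compound 4 `O=C(CSc1nnc(-c2ccncc2)o1)N/N=C/c1ccccc1F` differs from compound 1 by fluoro in place of hydrogen on an aromatic carbon. The two measured changes on the same ring bear on this step: a 1.5-fold higher number from compound 1 to compound 2 (0.19 log units; within the scatter) and a 1.0-fold higher number from compound 1 to compound 3 (0.00 log units; within the scatter). Neither a nitro nor a methyl in place of hydrogen on that ring moved the number beyond the scatter, so a fluoro in place of hydrogen is expected to leave the number near that of compound 1 as well. The step of a 1.0-fold higher number from compound 1 to compound 4 (0.01 log units; within the scatter) is therefore estimated to fall within the scatter. Compound 4 is expected to give about 17000 nM, in a range from 8500 nM to 34000 nM.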

Compound 4, half-maximal inhibitory concentration: 21500 nM
Compound 4: the middle estimate sits 1.3-fold (0.10 log units) below what was measured; low and high end bracket the measured number.
By their numbers in this assay, from the lowest: compounds 1, 3, 4 and 2 (each within the scatter of the next).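

In this assay, fluoro in place of hydrogen, ortho to a large group, gives a 1.3-fold higher number from compound 1 to compound 4 (0.11 log units; within the scatter) and so extends the flat picture to a substitution at this place on the ring. The comparisons with the other substituted rings agree, with a 1.3-fold higher number from compound 3 to compound 4 (0.11 log units; within the scatter) and a 1.2-fold lower number from compound 2 to compound 4 (0.08 log units; within the scatter), so compounds 1, 2, 3 and 4 cannot be told apart here. Nothing available offers an explanation for this flatness. Still open, from the compounds shown here alone, is whether an amine or a carboxylic acid on this ring would move the number beyond the scatter.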